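A few compounds are considered here, and "the series" means these few. Any claim that something is new, unique, unknown or untested is made for them only; others in the source may bear on it.

Of the compounds shown here, three with a shared core have been tested in an assay for displacement of a labelled ligand from metabotropic glutamate receptor 5 (Rattus norvegicus); a lower number here means a stronger inhibitor, a higher number a weaker inhibitor. Compound 1 `C(#Cc1ccccn1)C1=CC(Sc2ccncc2)CCC1` gives 43 nM, compound 2 `C(#Cc1ccccn1)C1=CCNCC1` gives 3400 nM, and compound 3 `O=S(=O)(Cc1ccccc1)N1CC=C(C#Cc2ccccn2)CC1` gives 389 nM. Among these three numbers compound 3 stands second highest: its nearest neighbour is compound 2, whose number is higher by a gap beyond the usual scatter, and the furthest is compound 1, whose number is lower, again beyond the scatter. Compound 4 `Cc1ccc(S(=O)(=O)N2CC=C(C#Cc3ccccn3)CC2)cc1` has not yet been measured; it differs from compound 3 by 4-methylphenyl in place of benzyl on a sulfonyl sulfur. Going by the values given here, no step between measured compounds covers such a change, so the expected step from compound 3 to compound 4 in this assay is a modest one, a 1.3-fold lower number from compound 3 to compound 4 (0.11 log units; within the scatter), with no confident direction. Compound 4 is estimated at 300 nM, within a range from 100 nM to 900 nM.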

Compound 4, inhibition constant: 12 nM
Compound 4: the middle estimate sits 25-fold (1.40 log units) above what was measured; the measured number lies below the stated range.
By their numbers in this assay, from the lowest: compound 4; then compound 1; then compound 3; then compound 2.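

Replacing benzyl with 4-methylphenyl on a sulfonyl sulfur gives a 32-fold lower number from compound 3 to compound 4 (1.51 log units; beyond the scatter) in this assay, although the two groups contain the same atoms. This position therefore responds strongly to how those atoms are arranged, not only to which atoms are present. No measurement here explains this difference.

The compounds shown leave open whether the improvement depends on the methyl group or on the ring being attached directly to the sulfonyl sulfur. A plain phenyl group there would separate these two possibilities, while 4-chlorophenyl would test another group in place of methyl.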